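The source may report more compounds than this note shows. Statements on the series, on what has been measured and on what is new or still open speak of the compounds shown alone.

Among the compounds with values here, in an ADME assay on microsomes from liver (Homo sapiens) for metabolic stability (on this read-out higher numbers stand for a longer-lived compound and lower numbers for a shorter-lived compound), three compounds have numbers so far. Compound 1, `CCCCC(=O)C1CCN(C(=O)c2cc3sccc3n2Cc2ccc(OC)cc2)CC1`, gives 0.105 h. Compound 2, `CCCNC(=O)C1CCN(C(=O)c2cc3[nH]ccc3n2Cc2ccc(OC)cc2)CC1`, gives 0.385 h. Compound 3, `CCCNC(=O)[C@@H]1C[C@H]2CCC[C@@H](C1)[C@@H]2NC(=O)c1cc2sc(-c3ccccc3)nc2n1Cc1ccc(OC)cc1`, gives 0.453 h, the highest of the three numbers; its gap to compound 2 lies within the usual scatter, while its gap to compound 1 lies beyond it. Compound 4, `CCCNC(=O)[C@@H]1C[C@H]2CCC[C@@H](C1)[C@@H]2NC(=O)c1cc2scnc2n1Cc1ccc(OC)cc1`, has not yet been measured in this assay. It differs from compound 3 in one place: hydrogen in place of phenyl on an aromatic carbon. Within the data shown here, no pair of measured compounds shows this same change, so no measured step tells how much it shifts the half-life; the expectation below rests only on the standing of compound 3 and on the size of the change. With that in mind, the step of a 1.1-fold lower number from compound 3 to compound 4 (0.05 log units; within the scatter) is expected to stay within the usual scatter, leaning lower rather than higher if at all. The estimate for compound 4 in this assay is therefore 0.4 h, with a likely range from 0.16 h to 1 h.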

Compound 4, half-life: 0.743 h
For compound 4 the middle estimate is 1.9-fold (0.27 log units) below the measured one; measured number inside the range.
By their numbers in this assay, from the lowest: compound 1; then compounds 2, 3 and 4 (each within the scatter of the next).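

In this assay, hydrogen in place of phenyl on this aromatic carbon, next to the ring nitrogen and next to the ring sulfur, gives a 1.6-fold higher number from compound 3 to compound 4 (0.21 log units; within the scatter), the first step measured at this position. The whole phenyl, with its six carbons, can therefore be exchanged for hydrogen here with the half-life staying within the scatter, and this read-out does not tell the two compounds apart. Nothing at hand bears on why the half-life responds in this way, so the step stands as an observation only.

On these data alone, whether a methyl, an amine or a pyridyl ring on this same carbon would move the half-life beyond the scatter stays open. As far as these compounds go, it is also open whether the same exchange would read alike with a different amide side chain, as this single pair is the only one that carries it.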